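From a Urea to a Benzamide on the Shared Core

This account rests on a few compounds, and the source may have more. Where it says the series, first, only, none or still open, it means among the compounds named here.

Compound 2, `COc1cc(-c2nn(-c3cccc(NC(=O)Nc4ccc(Cl)c(C(F)(F)F)c4)c3)cc2-c2ccncc2)ccc1Cl`, is known only through a limit in a functional assay on DU-145 cells (Homo sapiens) for inhibition, read by sulforhodamine B assay, with a stated time of 48 h; on this read-out higher numbers stand for lower toxicity in this test and lower numbers for higher toxicity in this test: compound 2 gives > 32500 nM, which is a limit of the assay and not a number. Compound 1, `COc1cc(-c2nn(-c3cccc(NC(=O)Nc4cccc(C(F)(F)F)c4)c3)cc2-c2ccncc2)ccc1Cl`, likewise gives > 50000 nM in this assay, again a limit. The step that the two limits leave unreadable from compound 1 to compound 2 therefore cannot be read because the limit of > 32500 nM in this assay, at which 1 of the 2 values shown sits, and the limit of > 50000 nM in this assay, at which 1 of the 2 values shown sits, are both limits.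

Compound 3, `COc1cc(-c2nn(-c3cccc(NC(=O)c4ccccc4)c3)cc2-c2ccncc2)ccc1Cl`, differs from compound 2 by phenyl in place of (4-chloro-3-(trifluoromethyl)phenyl)amino on a carbonyl carbon. For the measured compounds named here, the only measured step, the one from compound 1 to compound 2, gives no size to carry over, so no direction beyond the scatter can be drawn from it. With both measured compounds sitting at limits, the step from compound 2 to compound 3 is expected to be about a step that the limit leaves unreadable from compound 2 to compound 3 in this assay. Compound 3 is therefore estimated at 50000 nM, within a range from 15000 nM to 100000 nM.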

Compound 3, concentration lethal to 50% of the cells: > 100000 nM
Compound 3 ended at the assay's limit; the forecaster's own chance of this, stated with the estimate: 70%; at least 2.0-fold (0.30 log units) between middle value and limit.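

For the compounds shown here, all three compounds sit at limits of the assay, so no step among compound 1, compound 2 and compound 3 can be read. The compounds shown leave open what concentration of any of them would reach the read-out in this assay, and whether these changes alter it at all.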